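The source may report more compounds than this note shows. Statements on the series, on what has been measured and on what is new or still open speak of the compounds shown alone.

Measured so far in a functional assay on HEK293 cells for agonist activity at 5-hydroxytryptamine receptor 4 (Homo sapiens), read by cAMP accumulation; a higher number here means that more compound is needed for the effect, a lower number that less compound is needed:
- compound 1 `COc1cc(N)c(Cl)cc1C(=O)NCCN1CCNCC1` gives 501 nM
- compound 2 `CCCCCN1CCC(NC(=O)c2cc(Cl)c(N)cc2OC)CC1` gives 25.1 nM
- compound 3 `COc1cc(N)c(Cl)cc1C(=O)NC1CCN(CCN2C(=O)c3ccccc3C2=O)CC1` gives 631 nM

Compound 2 stands lowest of the three numbers in this assay; both compound 1 and compound 3 lie well above it, and each of those gaps is beyond the usual scatter, so compound 2 is the most potent of the three as measured.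

Compound 4 `COc1cc(N)c(Cl)cc1C(=O)NC1CCN(CCCCCN2CCCCC2)CC1` differs from compound 2 in one place: piperidin-1-yl in place of hydrogen on a saturated chain carbon, five bonds along the chain from an amine nitrogen in a ring. The chain itself is kept; only its end carbon now carries the ring. Among the measured compounds shown here, the only other compound bearing a substituted chain on the ring nitrogen, compound 3, sits among the higher numbers, but no single-point step links it to compound 2, so its value serves only as a rough caution.

Compound 4 is expected to come out close to compound 2, with a modest move toward a higher number; the estimated step of a 2.4-fold higher number from compound 2 to compound 4 (0.38 log units; beyond the scatter) is taken as small and uncertain in direction. The estimate for compound 4 is 60 nM, with a range from 15 nM to 250 nM.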

Compound 4, half-maximal effective concentration: 5.01 nM
Estimate against measurement, compound 4: 12-fold (1.08 log units) above; measured number outside the range, below it.
By their numbers in this assay, from the lowest: compound 4; then compound 2; then compounds 1 and 3 (each within the scatter of the next).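

In this assay, piperidin-1-yl in place of hydrogen on a saturated chain carbon, five bonds along the chain from an amine nitrogen in a ring, gives a 5.0-fold lower number from compound 2 to compound 4 (0.70 log units; beyond the scatter) and thus a modest gain beyond the scatter. Among the compounds shown here, this is the first single-change step, and it shows that this chain position accepts a six-membered non-aromatic ring with one hetero atom without any loss in this read-out. Nothing available explains the gain.

On these data alone, whether the gain depends on the ring itself or on its amine nitrogen remains open, and a morpholine or a dimethylamino group at the same chain position would separate the two. A shorter or longer chain carrying the piperidin-1-yl group would show how much the distance along the chain matters.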